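Phenyl in place of methyl on a pyrazole-type ester scaffold

A few compounds are considered here, and "the series" means these few. Any claim that something is new, unique, unknown or untested is made for them only; others in the source may bear on it.

Measured compounds:
compound 1, `CCOC(=O)c1nn(-c2ccccc2)c(-c2ccc(OC)cc2OC)c1-c1ccccc1`, 20.8%
compound 2, `CCOC(=O)c1nn(-c2ccc(Cl)cc2)c(-c2ccc(OC)cc2OC)c1C`, 2.22%

Both were tested in a functional assay on the whole organism (strain albino) for inhibition, with Rattus norvegicus as the target, read by paw edema, with stated times of 30 min and 3 h, at a dose of 25 mg/kg by the intraperitoneal route; on this read-out lower numbers stand for less inhibition and higher numbers for more inhibition at the one dose given (going by the name of the read-out). Compound 2 stands lowest of the two numbers; its nearest neighbour is compound 1, whose value lies higher by a gap beyond the usual scatter. Among the compounds with values here, the two structures differ in more than one place, so no single step between them is given; the numbers only show that compound 1 gives 20.8% while compound 2 gives 2.22%.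

Compound 3, `CCOC(=O)c1nn(-c2ccc(Cl)cc2)c(-c2ccc(OC)cc2OC)c1-c1ccccc1`, has not yet been measured. It differs from compound 2 by phenyl in place of methyl on an aromatic carbon, on an aromatic carbon of a five-membered aromatic ring with 2 nitrogen, next to the ring atom that bears an ethoxycarbonyl group.

Compound 1 also bears a phenyl group at that carbon and gives the higher value, so an upward step in this assay is expected, though the other difference between compound 1 and compound 2 leaves the size uncertain. The step expected for compound 3 is a number 11.8 percentage points higher from compound 2 to compound 3 (beyond the scatter). Compound 3 is accordingly estimated at 14%, within a range from 3% to 27%.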

Compound 3, a percentage reported as inhibition, in the whole organism at one dose (the size of the read-out at that dose, not a potency): 15%
For compound 3 the middle estimate is 1 percentage points below the measured one, within the range that was stated.
By their numbers in this assay, from the lowest: compound 2; then compounds 3 and 1 (each within the scatter of the next).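

In this assay phenyl in place of methyl at this carbon gives a number 12.8 percentage points higher from compound 2 to compound 3 (beyond the scatter) and so ties the rise to this one change, with the 4-chlorophenyl group held in place, although the step is modest. With phenyl kept at this carbon, chloro in place of hydrogen on an aromatic carbon gives a number 5.8 percentage points lower from compound 1 to compound 3 (within the scatter) and leaves compound 1 and compound 3 within the scatter of each other at this dose. Nothing at hand bears on what lies behind the step at this carbon.

The compounds shown carry only methyl and phenyl at this carbon, so how an ethyl group or a benzyl group would read there stays open. Each compound is also seen at a single dose, which leaves their relative potency open.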